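The source may hold more compounds than are shown below. What is called first, only, known or untested is meant among the compounds shown, and "the series" means these compounds.

Measured so far:
compound 1 `Cc1c(C)c(S(=O)(=O)N2CCC(N3CCC(C)CC3)CC2)c(C)c2c1OC(C)(C)C2` — 1.2 nM
compound 2 `Cc1cc(C)c(S(=O)(=O)N2CCN(C3CCN(C)CC3)CC2)c(C)c1` — 426 nM
compound 3 `COc1ccc(-c2cccc(S(=O)(=O)N3CCC(N4CCC(C)CC4)CC3)c2)cc1` — 23 nM

In a functional assay on DLD-1 cells (Homo sapiens) for antiproliferative activity, read by CellTiter-Glo, with a stated time of 72 h (on this read-out lower numbers stand for stronger inhibition and higher numbers for weaker inhibition), compound 3 gives 23 nM, the second highest of the three numbers. Compound 2 gives 426 nM, a higher number that lies beyond the scatter, while compound 1 gives 1.2 nM, a lower number that also lies beyond the scatter. Compound 4 `Cc1cc(C)cc(-c2cccc(S(=O)(=O)N3CCC(N4CCC(C)CC4)CC3)c2)c1` has not yet been measured. It differs from compound 3 in a single place: 3,5-dimethylphenyl in place of 4-methoxyphenyl on an aromatic carbon. Going by the values given here, no pair of the measured compounds differs in only one place, so there is no earlier step of the same kind to lean on; compound 1 and compound 2 differ from compound 3 in several parts at once, and their numbers cannot be traced to this exchange alone. With the bulk of the molecule shared between compound 3 and compound 4, the expected step is small, in neither direction beyond the scatter: a 1.2-fold lower number from compound 3 to compound 4 (0.06 log units; within the scatter). Compound 4 is therefore estimated to give about 20 nM, with a likely range from 5 nM to 80 nM.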

Compound 4, half-maximal inhibitory concentration: 41 nM
Compound 4: the middle estimate sits 2.1-fold (0.31 log units) below what was measured; the range from low to high includes it.
By their numbers in this assay, from the lowest: compound 1; then compounds 3 and 4 (each within the scatter of the next); then compound 2.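

In this assay, placing 3,5-dimethylphenyl where 4-methoxyphenyl stood on this aromatic carbon gives a 1.8-fold higher number from compound 3 to compound 4 (0.25 log units; within the scatter), so the two compounds cannot be told apart on this read-out. Going by these compounds alone, this is the first comparison in the set that differs in one place only, and it shows that this position can carry an aryl group with two methyl groups and no oxygen while the number stays within the scatter. No measurement shown here offers a reason for this outcome.

The exchange moves the substituents and swaps their type at once, so a plain 4-methylphenyl group would be needed to separate those two changes. From the compounds shown here alone, it also stays open whether a group of a different kind at this position, such as a carboxylic acid or a morpholine ring, would keep the number in this range.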